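The compounds below may be only part of what the source reports. "The series", "measured", "known", "first", "only" and "open" are said of these compounds alone.

Working notes on the series. Compound 1 `CC/C=C\[C@H](C)[C@H](OC(N)=O)[C@@H](C)[C@H](O)[C@@H](C)C/C(C)=C\[C@H](C)[C@@H](O)[C@@H](C)/C=C\[C@@H](O)C[C@@H]1OC(=O)[C@H](C)C[C@H]1C` carries the six-membered lactone ring; in a functional assay on NCI/ADR-RES cells (Homo sapiens) for antiproliferative activity (a lower number here means a stronger inhibitor of growth, a higher number a weaker inhibitor of growth), compound 1 gives 140 nM. Compound 2 `CC/C=C\[C@H](C)[C@H](OC(N)=O)[C@@H](C)[C@H](O)[C@@H](C)C/C(C)=C\[C@H](C)[C@@H](O)[C@@H](C)/C=C\[C@@H](O)C[C@H]1CCC(=O)O1` carries the five-membered ring, and compound 2 gives 730 nM; the step is a 5.2-fold higher number from compound 1 to compound 2 (0.72 log units; beyond the scatter). Compound 3 `CC/C=C\[C@H](C)[C@H](OC(N)=O)[C@@H](C)[C@H](O)[C@@H](C)C/C(C)=C\[C@H](C)[C@@H](O)[C@@H](C)/C=C\[C@@H](O)C[C@H](O)[C@H](C)C[C@H](C)C(=O)OC` has the open chain in place of either ring, and compound 3 gives 10000 nM, the highest number of the three: it lies a 71-fold higher number from compound 1 to compound 3 (1.85 log units; beyond the scatter) and a 14-fold higher number from compound 2 to compound 3 (1.14 log units; beyond the scatter), both well beyond the scatter.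

Compound 4 `CC/C=C\[C@H](C)[C@H](OC(N)=O)[C@@H](C)[C@H](O)[C@@H](C)C/C(C)=C\[C@H](C)[C@@H](O)[C@@H](C)/C=C\[C@@H](O)C[C@@H]1OC(=O)[C@H](C)[C@@H](OC)[C@H]1C` has not yet been measured. It differs from compound 3 thus: a group of 11 heavy atoms (8 carbon, 3 oxygen; one six-membered non-aromatic ring with 1 hetero atom) in place of a group of 11 heavy atoms (8 carbon, 3 oxygen; no ring), on a saturated chain carbon, two bonds along the chain from a double-bonded chain carbon and an oxygen on a saturated carbon. Among the compounds with values here, the steps that bear on this run in the opposite direction, from ring to open chain, and were large in both cases, a 71-fold higher number from compound 1 to compound 3 (1.85 log units; beyond the scatter) and a 14-fold higher number from compound 2 to compound 3 (1.14 log units; beyond the scatter); the six-membered ring in particular gave the lowest number. Re-closing to a six-membered ring should therefore give a large drop in the number for compound 4, though its ring is not identical to that of compound 1, which leaves some room. For compound 4 the expected value in this assay is 220 nM (range 60 nM to 900 nM), an expected step of a 45-fold lower number from compound 3 to compound 4 (1.66 log units; beyond the scatter).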

Compound 4, concentration for 50% growth inhibition: 250 nM
For compound 4 the middle estimate is 1.1-fold (0.06 log units) below the measured one, within the range that was stated.
By their numbers in this assay, from the lowest: compounds 1 and 4 (each within the scatter of the next); then compound 2; then compound 3.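

In this assay, closing the open chain to a six-membered ring that carries methoxy gives a 40-fold lower number from compound 3 to compound 4 (1.60 log units; beyond the scatter), so the large effect of the ring at this place also holds for a ring other than that of compound 1. The advantage of the six-membered ring over the five-membered one also survives this substitution, with a 2.9-fold lower number from compound 2 to compound 4 (0.47 log units; beyond the scatter) still beyond the scatter. Methoxy in place of hydrogen on a saturated ring carbon gives a 1.8-fold higher number from compound 1 to compound 4 (0.25 log units; within the scatter), within the scatter, so the methoxy of compound 4 leaves the number indistinguishable from that of compound 1.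

From the compounds shown here alone, whether a hydroxyl or an ethoxy at that ring carbon would hold this level, and what the configuration of the methoxy-bearing carbon contributes, remains open. No independent data bear on the reason for these steps.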